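Methylsulfonyl in Place of Acetyl on the Sulfonate Ester

The compounds below may be only part of what the source reports. "The series", "measured", "known", "first", "only" and "open" are said of these compounds alone.

Compound 1 `CNC(=O)/C=C1/COc2cc(OS(=O)(=O)c3ccccc3)ccc21`: 0%
Compound 2 `CNC(=O)/C=C1/COc2cc(OS(=O)(=O)c3ccc([N+](=O)[O-])cc3)ccc21`: 13%
Compound 3 `CNC(=O)/C=C1/COc2cc(OS(=O)(=O)c3ccc(C(C)=O)cc3)ccc21`: 0%

In an assay (strain Sprague-Dawley) for inhibition of Amine oxidase [flavin-containing] B (Rattus norvegicus), read by spectrophotometry, with a stated time of 5 min, tested at 10 uM (a higher number here means more inhibition at the concentration tested (going by the name of the read-out), a lower number less inhibition), compound 3 stands level with compound 1 at the digits printed, and together they are the lowest of the three numbers; its nearest neighbour is compound 1, with no change at the digits printed from compound 1 to compound 3 (within the scatter), and its furthest is compound 2, with a number 13 percentage points lower from compound 2 to compound 3 (beyond the scatter). Compound 4 `CNC(=O)/C=C1/COc2cc(OS(=O)(=O)c3ccc(S(C)(=O)=O)cc3)ccc21` differs from compound 3 by methylsulfonyl in place of acetyl on an aromatic carbon. Both steps at this aromatic carbon bear on it: no change at the digits printed from compound 1 to compound 3 (within the scatter), and a number 13 percentage points higher from compound 1 to compound 2 (beyond the scatter). Only the nitro group moved the number beyond the scatter, and the acetyl group did not. Compound 4 is therefore expected to show at most a small step, a number 5 percentage points higher from compound 3 to compound 4 (within the scatter), and its value in this assay is estimated at 5%, within a range of 0% to 20%.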

Compound 4, a percentage reported as inhibition, at one concentration (the size of the read-out at that concentration, not a potency): 0%
Estimate against measurement, compound 4: 5 percentage points above; measured number inside the range.
By their numbers in this assay, from the lowest: compounds 1, 3 and 4 (each within the scatter of the next); then compound 2.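

In this assay, methylsulfonyl behaves like acetyl at this aromatic carbon, with no change at the digits printed from compound 3 to compound 4 (within the scatter) and no change at the digits printed from compound 1 to compound 4 (within the scatter) as well, so a second group in place of hydrogen leaves the reading unmoved. Nitro alone stands apart, with a number 13 percentage points lower from compound 2 to compound 4 (beyond the scatter) marking the gap to methylsulfonyl. Nothing available accounts for that gap.

As far as these compounds go, whether an amine or a carboxylic acid at this aromatic carbon would side with nitro or with the other groups remains open. So does whether compounds sharing one printed value at this single concentration would also match at others.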